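Chromone dithiocarbamates: morpholine to piperidine swap

A few compounds are considered here, and "the series" means these few. Any claim that something is new, unique, unknown or untested is made for them only; others in the source may bear on it.

Measured so far:
- compound 1, `Cc1ccc2c(=O)c(CSC(=S)N3CCCCC3)coc2c1`: 800 nM
- compound 2, `O=c1c(CSC(=S)N2CCOCC2)coc2ccccc12`: 4000 nM

Going by the values given here, in a functional assay on MCF7 cells (Homo sapiens) for antiproliferative activity, read by MTT assay, with a stated time of 72 h (on this read-out lower numbers stand for stronger inhibition and higher numbers for weaker inhibition), compound 2 gives 4000 nM, the higher of the two numbers so far; compound 1 gives 800 nM in this assay, a gap that lies beyond the scatter. Among the compounds with values here, compound 1 and compound 2 differ in more than one place, so no single step between them can be read.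

Compound 3, `O=c1c(CSC(=S)N2CCCCC2)coc2ccccc12`, differs from compound 2 in one place: piperidin-1-yl in place of morpholin-4-yl on a thiocarbonyl carbon. Compound 1 also carries piperidin-1-yl on its thiocarbonyl carbon, and its number is the lower one, so the step from compound 2 to compound 3 is expected to go downward, by an amount estimated at a 2.7-fold lower number from compound 2 to compound 3 (0.43 log units; beyond the scatter). Compound 3 is accordingly expected to give about 1500 nM in this assay, with a range from 600 nM to 4000 nM.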

Compound 3, half-maximal inhibitory concentration: 1700 nM
Compound 3: the middle estimate sits 1.1-fold (0.05 log units) below what was measured, and the stated range covers the measured number.
By their numbers in this assay, from the lowest: compound 1; then compound 3; then compound 2.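

In this assay the thiocarbonyl carbon now has a step of its own: on an unchanged core, piperidin-1-yl in place of morpholin-4-yl gives a 2.4-fold lower number from compound 2 to compound 3 (0.37 log units; beyond the scatter) as a modest change beyond the scatter. Compound 3 also isolates the second place, since hydrogen in place of methyl on an aromatic carbon gives a 2.1-fold higher number from compound 1 to compound 3 (0.33 log units; beyond the scatter) and is likewise modest, so the difference between compound 1 and compound 2 now resolves into two readable single changes. No accompanying measurement bears on either step, so neither can be assigned a cause.

From the compounds shown here alone, each place rests on one change only, so it remains open whether another amine on the thiocarbonyl carbon, such as pyrrolidin-1-yl or 4-methylpiperazin-1-yl, would follow the same direction. Also open, going by these compounds, is how chlorine or methoxy would compare with methyl on the aromatic carbon.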